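The source may report more compounds than this note shows. Statements on the series, on what has been measured and on what is new or still open speak of the compounds shown alone.

Measured so far in an assay on HEK293 cells for displacement of a labelled ligand from metabotropic glutamate receptor 5 (Rattus norvegicus); on this read-out higher numbers stand for weaker inhibition and lower numbers for stronger inhibition:
compound 1, `O=C(Nc1cc(-c2ccccc2)nn1-c1ccccc1)c1cccc(C(F)(F)F)c1`: compound 1 gives 1650 nM.
compound 2, `COc1ccc(C(=O)Nc2cc(-c3ccccc3)nn2-c2ccccc2)cc1`: compound 2 gives 420 nM.
compound 3, `NC(=O)c1ccc(C(=O)Nc2cc(-c3ccccc3)nn2-c2ccccc2)cc1`: compound 3 gives > 10000 nM, which is a limit of the assay and not a number.

Compound 3 therefore stands at the weak end of the three, at the limit of > 10000 nM in this assay, at which 1 of the 3 values shown sits; where exactly it lies beyond that point is not known. The two steps into it were both beyond the scatter: an at least 6.0-fold higher number from compound 1 to compound 3 (0.78 log units; beyond the scatter) and an at least 23-fold higher number from compound 2 to compound 3 (1.37 log units; beyond the scatter). For the measured compounds named here, the step between the other two compounds ran the opposite way, a 3.9-fold lower number from compound 1 to compound 2 (0.59 log units; beyond the scatter), so within this small set the carbamoyl on the aromatic carbon is the one change that pushed a compound out to the limit.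

Compound 4, `O=C(O)c1ccc(C(=O)Nc2cc(-c3ccccc3)nn2-c2ccccc2)cc1`, differs from compound 3 by hydroxy in place of amino on a carbonyl carbon. Going by the values given here, no measured pair exchanges these two groups directly; the only steps that bear on it are the two leading into compound 3, both of which end at a limit. The change keeps the polar carbonyl group on the same aromatic carbon, so the expectation is that the step that the limit leaves unreadable from compound 3 to compound 4 shows no clear movement beyond the scatter, in either direction. Compound 4 is accordingly estimated at 15000 nM, with a range from 4000 nM to 60000 nM, and is more likely than not to be reported again only as a limit.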

Compound 4, inhibition constant: > 10000 nM
Compound 4: only a limit was reported (the forecaster's own chance of this, stated with the estimate: 65%); the middle value is on the limit's open side.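

In this assay compound 4 gives > 10000 nM, which is a limit of the assay and not a number. The loss seen with carbamoyl is therefore not confined to that one group, since carboxy on the same aromatic carbon also gives a step beyond the scatter against methoxy, an at least 23-fold higher number from compound 2 to compound 4 (1.37 log units; beyond the scatter), and against the 3-(trifluoromethyl)phenyl on the carbonyl carbon, an at least 6.0-fold higher number from compound 1 to compound 4 (0.78 log units; beyond the scatter). The step from compound 3 to compound 4 cannot be read, so hydroxy in place of amino on the carbonyl carbon has no measurable size here, and any order between the two compounds remains unknown: the limit of > 10000 nM in this assay, at which 2 of the 4 values shown sit.

The compounds shown leave open how far past the limit compound 3 and compound 4 lie, and whether a methyl ester or a methyl amide on the same aromatic carbon would return a number short of it. They also leave open whether the loss follows the carbonyl itself, a question that a ketone or a nitrile at that place would address.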